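The compounds below may be only part of what the source reports. "The series", "measured", "known", "first", "only" and "open" are said of these compounds alone.

Three compounds that share one core were compared in an assay on isolated protein for inhibition of Rho-associated protein kinase 2 (Homo sapiens), read by radiometric assay; on this read-out lower numbers stand for stronger inhibition and higher numbers for weaker inhibition. Compound 1 `CCCCCCOC(=O)c1cccc(-c2cc(C(=O)Nc3ccncc3)ccc2CN)c1` gives 22 nM. Compound 2 `NCc1ccc(C(=O)Nc2ccncc2)cc1-c1cccc(C(=O)OCc2ccccc2)c1` gives 45 nM. Within the data shown here, compound 3 `NCc1ccc(C(=O)Nc2ccncc2F)cc1-c1cccc(C(=O)O)c1` differs from the other two in more than one place, so no single step is drawn to it; compound 3 gives 55 nM. On these three numbers compound 2 holds the second highest value: the number of compound 3 lies within the scatter of it, while compound 1 sits lower by a step that is beyond the scatter.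

Among the measured compounds shown here, the only single-point step measured among them is a 2.0-fold higher number from compound 1 to compound 2 (0.31 log units; beyond the scatter), a modest loss. Compound 4 `CCCOC(=O)c1cccc(-c2cc(C(=O)Nc3ccncc3)ccc2CN)c1` is reached from compound 2 by a change at the same position: ethyl in place of phenyl on a saturated chain carbon bound to an oxygen next to a carbonyl group. Propyl stands between benzyl and the longer hexyl chain of compound 1, and the measured step shows that the hexyl ester of compound 1, at 22 nM, sits lower than the benzyl ester. On that basis a small gain is expected for compound 4, an expected step of a 1.5-fold lower number from compound 2 to compound 4 (0.18 log units; within the scatter) in this assay. Compound 4 is therefore estimated at 30 nM, with an expected range from 12 nM to 80 nM.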

Compound 4, half-maximal inhibitory concentration: 1.4 nM
Estimate against measurement, compound 4: 21-fold (1.33 log units) above; measured number outside the range, below it.
By their numbers in this assay, from the lowest: compound 4; then compound 1; then compounds 2 and 3 (each within the scatter of the next).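

In this assay, the propoxycarbonyl group of compound 4 changes the picture of this position: the step from benzyloxycarbonyl is a 32-fold lower number from compound 2 to compound 4 (1.51 log units; beyond the scatter), and the step from the hexyl ester is a 16-fold lower number from compound 1 to compound 4 (1.20 log units; beyond the scatter). The earlier pair had shown only a modest difference between the hexyl and benzyl esters, which gave no sign that this position could move the number so far. Both new steps are large and point the same way, so among compound 1, compound 2 and compound 4 the number does not follow a simple order in which a longer chain on the ester gives a lower or a higher value, and the propyl ester lies well under both of its larger neighbours; nothing measured here explains this sharp drop.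

The compounds shown leave open whether propyl marks a true minimum at this position, since a methyl, ethyl or butyl chain could fall on either side of it. They also leave open how a branched isopropyl ester, or an amide in place of the ester, would read on the same core.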